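The source may report more compounds than this note shows. Statements on the series, on what has been measured and on what is new or still open speak of the compounds shown alone.

Compound 1 `Cc1ccc(SCc2ccc(/C=C/C(=O)Nc3ccccc3N)cc2)cc1` gives 21.7% in a functional assay on HeLa cells (Homo sapiens) for inhibition, read by CCK-8 assay, with a stated time of 72 h, tested at 8 uM; on this read-out higher numbers stand for more inhibition of growth at the one concentration tested and lower numbers for less inhibition of growth. That is the lowest of the three numbers measured: compound 2 `COc1ccc(SCc2ccc(C(=O)Nc3ccccc3N)cc2)cc1` gives 79.7% and compound 3 `Nc1ccccc1NC(=O)c1ccc(CSc2ccc(F)cc2)cc1` gives 79.3%, each beyond the scatter above compound 1, although both differ from compound 1 in more than one place. Among the measured compounds shown here, the only single-place step measured, a number 0.4 percentage points lower from compound 2 to compound 3 (within the scatter), concerns the aryl substituent and not the group on sulfur. Compound 4 `Nc1ccccc1NC(=O)/C=C/c1ccc(CSCCc2ccccc2)cc1` arises from compound 1 by phenethyl in place of 4-methylphenyl on a sulfur. For the measured compounds named here, no measured step bears on this exchange. The expected step is a number 4.3 percentage points higher from compound 1 to compound 4 (within the scatter), which is estimated to remain within the scatter. Compound 4 is therefore estimated at 26%, with a range from 8% to 50%.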

Compound 4, percent growth inhibition at one concentration: 3.57%
Estimate against measurement, compound 4: 22.4 percentage points above; the measured number lies below the stated range.
By their numbers in this assay, from the lowest: compound 4; then compound 1; then compounds 3 and 2 (each within the scatter of the next).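

In this assay, phenethyl in place of 4-methylphenyl on the sulfur gives a number 18.1 percentage points lower from compound 1 to compound 4 (beyond the scatter), so this position responds to the exchange, unlike the aryl substituent change measured earlier. Both groups hold one six-membered aromatic ring of carbon only and no hydrogen-bond donors or acceptors, so those counts do not separate them. Nothing measured here explains the step. Going by these compounds, whether a longer chain or an amine on the sulfur would give a different number remains open. So does whether phenethyl would produce a similar step on the core of compound 2.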